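The source may hold more compounds than are shown below. What is called first, only, known or untested is meant among the compounds shown, and "the series" means these compounds.

Measured compounds:
compound 1, `N/C(=N\NC(=S)N1CCCCCC1)c1ccccn1`, 84%
compound 2, `Cc1ccnc(/C(N)=N/NC(=S)N2CCSCC2)c1`, 76.8%
compound 3, `N/C(=N\NC(=S)N1CCSCC1)c1ccccn1`, 72.4%

In a functional assay on MCF7 cells (Homo sapiens) for cytotoxicity, read by MTT assay, with a stated time of 72 h, tested at 100 uM (a higher number here means more inhibition of growth at the concentration tested, a lower number less inhibition of growth), compound 1 gives 84%, compound 2 gives 76.8% and compound 3 gives 72.4%. The number of compound 1 lies beyond the scatter from that of compound 3, while compound 1 and compound 2 sit within the scatter of each other. Compound 3 and compound 2 differ by methyl in place of hydrogen on an aromatic carbon, a change that gave a number 4.4 percentage points higher from compound 3 to compound 2 (within the scatter). How the core of compound 1 differs from the core of compound 3 is not broken down here.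

Compound 4, `Cc1cccc(/C(N)=N/NC(=S)N2CCCCCC2)n1`, differs from compound 1 by methyl in place of hydrogen on an aromatic carbon. This is the same kind of change as that from compound 3 to compound 2, but not the same: there the methyl sits opposite the ring nitrogen, here next to the ring nitrogen. The step is expected to be small, about a number 2 percentage points higher from compound 1 to compound 4 (within the scatter), because the earlier methyl step gave a number 4.4 percentage points higher from compound 3 to compound 2 (within the scatter). Compound 4 is therefore estimated at 86% in this assay, between 72% and 96%.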

Compound 4, percent growth inhibition at one concentration: 70.2%
Compound 4: the middle estimate sits 15.8 percentage points above what was measured; the measured number lies below the stated range.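

In this assay, methyl in place of hydrogen on an aromatic carbon gave a number 13.8 percentage points lower from compound 1 to compound 4 (beyond the scatter), so the change did not carry over from one core to the other as a step of fixed size: the same change on two cores in this assay, a number 4.4 percentage points higher (within the scatter) from compound 3 to compound 2 and a number 13.8 percentage points lower (beyond the scatter) from compound 1 to compound 4, 18.2 percentage points apart, beyond the scatter of two such steps. The two steps differ both in the core and in where the methyl sits, with the methyl of compound 4 next to the ring nitrogen and that of compound 2 elsewhere on the ring, so the comparison cannot tell which of these two differences accounts for the gap. Among these compounds, it rests on only two steps and shows neither why the number of compound 4 lies lower nor how the change would behave on any further core.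

The compounds shown leave open what a methyl next to the ring nitrogen would do on the core of compound 3, which would separate place from core. Also open, from the compounds shown here alone, is how an ethyl, a methoxy, a chlorine or an amine would compare with methyl on that same aromatic carbon.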